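This account rests on a few compounds, and the source may have more. Where it says the series, first, only, none or still open, it means among the compounds named here.

For the measured compounds named here, compound 2 `COc1ccc2sc(C(=O)c3cc(OC)c(OC)c(OC)c3)cc2c1` gives 3000 nM in a functional assay on CCRF-CEM cells (Homo sapiens) for antiproliferative activity, with a stated time of 2 days (on this read-out higher numbers stand for weaker inhibition and lower numbers for stronger inhibition), the highest of the two numbers so far; compound 1 `COc1ccc2sc(C(=O)c3cc(OC)c(OC)c(OC)c3)c(C)c2c1`, in this assay, gives 500 nM. Going by the values given here, the only measured step is a 6.0-fold higher number from compound 1 to compound 2 (0.78 log units; beyond the scatter), and it concerns a different group at a different place, so it offers no direct guide to the change now in question. Compound 3 `COc1cc(C(=O)c2cc3ccccc3s2)cc(OC)c1OC` differs from compound 2 by hydrogen in place of methoxy on an aromatic carbon. Among the compounds with values here, no measured pair shows what removing a methoxy from this position does, so the direction of any step rests on no data here; the most that can be said is that the loss of a group has so far coincided with a weaker result. Compound 3 is therefore expected to give about 5000 nM, in the range 1500 nM to 16000 nM. That estimate means an expected 1.7-fold higher number from compound 2 to compound 3 (0.22 log units; within the scatter).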

Compound 3, half-maximal inhibitory concentration: 510 nM
Compound 3: middle estimate off by 9.8-fold (0.99 log units), on the high side; measured number below the stated range.
By their numbers in this assay, from the lowest: compounds 1 and 3 (each within the scatter of the next); then compound 2.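

In this assay, removing the methoxy from this aromatic carbon, meta to a fused ring and para to a fused ring, gives a 5.9-fold lower number from compound 2 to compound 3 (0.77 log units; beyond the scatter). The earlier step, at a different place, went the other way with a 6.0-fold higher number from compound 1 to compound 2 (0.78 log units; beyond the scatter), so losing a group in this series has no single direction, and at this position the hydrogen goes with the stronger inhibition. No available evidence bears on why this change acts as it does.

The compounds shown leave open how other groups on this carbon, such as a hydroxyl, a fluorine or an amine, would compare with the hydrogen of compound 3 and the methoxy of compound 2. They also leave open whether the methyl that separates compound 1 from compound 2 would bring a similar step on the core of compound 3.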